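From compound 1 to its fluoro analogue compound 3

A few compounds are considered here, and "the series" means these few. Any claim that something is new, unique, unknown or untested is made for them only; others in the source may bear on it.

Compound 1 `O=C1C=CCC/C1=C\C=C\c1ccccc1` gives 4200 nM as a number
Compound 2 `O=C1C=CCC/C1=C\C(Br)=C\c1ccccc1` gives > 10000 nM as a limit

Among the compounds with values here, in a functional assay on Bel-7402 cells (Homo sapiens) for cytotoxicity, read by MTT assay, with a stated time of 72 h (a lower number here means a stronger inhibitor, a higher number a weaker inhibitor), compound 1 gives 4200 nM as the only exact number so far. Compound 2 stands at > 10000 nM which is a limit. Compound 3 `O=C1C=CCC/C1=C\C=C\c1ccc(F)cc1` differs from compound 1 by fluoro in place of hydrogen on an aromatic carbon with fluoro in place of hydrogen on an aromatic carbon. Within the data shown here, the one measured step of an at least 2.3-fold higher number from compound 1 to compound 2 (0.37 log units; beyond the scatter) lies on the chain and not on the aromatic ring, so it offers little guidance here. What is expected is a 1.1-fold lower number from compound 1 to compound 3 (0.04 log units; within the scatter) within the scatter and without a clear direction. In this assay compound 3 is estimated at 3800 nM with a range from 1500 nM to 9000 nM as its expected spread.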

Compound 3, half-maximal inhibitory concentration: 1800 nM
Compound 3: the middle estimate sits 2.1-fold (0.32 log units) above what was measured; low and high end bracket the measured number.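

On the aromatic ring of the shared core, the place para to a large group accepts fluoro in place of hydrogen, and in this assay this gives a 2.3-fold lower number from compound 1 to compound 3 (0.37 log units; beyond the scatter). This is the first change shown that lowers the number, whereas the bromo change on the chain raised it. Nothing given here accounts for the gain.

Going by these compounds, it remains open whether chloro, methoxy or an amine at this same place would lower the number as well. Also open, on these data alone, is whether fluoro elsewhere on the aromatic ring would do so.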